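This account rests on a few compounds, and the source may have more. Where it says the series, first, only, none or still open, it means among the compounds named here.

Measured compounds in a functional assay on HL-60 cells (Homo sapiens) for cytotoxicity, read by MTT assay, with a stated time of 48 h; a lower number here means a stronger inhibitor, a higher number a weaker inhibitor:
compound 1 `CCCCCCCCCC(=O)N[C@H](C(=O)Nc1ccn([C@H]2O[C@@H](CO)[C@H](O)[C@H]2O)c(=O)n1)C(C)C`: 2040 nM
compound 2 `CCCCCCCCCC(=O)N[C@@H](CCCNC(=N)N)C(=O)Nc1ccn([C@H]2O[C@@H](CO)[C@H](O)[C@H]2O)c(=O)n1`: 584 nM
compound 3 `CCCCCCCCCCCCCCCCCC(=O)N[C@@H](CCCNC(=N)N)C(=O)Nc1ccn([C@H]2O[C@@H](CO)[C@H](O)[C@H]2O)c(=O)n1`: 1700 nM

Compound 4 `CCCCCCCCCCCCCCCCCC(=O)N[C@H](C(=O)Nc1ccn([C@H]2O[C@@H](CO)[C@H](O)[C@H]2O)c(=O)n1)C(C)C` is not yet measured. It differs from compound 3 by a group of 3 heavy atoms (3 carbon; no ring) in place of a group of 7 heavy atoms (4 carbon, 3 nitrogen; no ring), on a saturated chain carbon bound to an amide-type nitrogen and a carbonyl carbon. The same change has been made once before among measured compounds, from compound 2 to compound 1, where it reads a group of 3 heavy atoms (3 carbon; no ring) in place of a group of 7 heavy atoms (4 carbon, 3 nitrogen; no ring), on a saturated chain carbon bound to an amide-type nitrogen and a carbonyl carbon and gave a 3.5-fold higher number from compound 2 to compound 1 (0.54 log units; beyond the scatter). The two "place" descriptions agree word for word, so this is the same change on a different core. The cores differ by octyl in place of hydrogen on a saturated chain carbon, nine bonds along the chain from a carbonyl carbon, a change that on its own gave a 2.9-fold higher number from compound 2 to compound 3 (0.46 log units; beyond the scatter).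

Compound 1 and compound 3 stand close to one another in this assay, within the usual scatter. Among the measured compounds shown here, with only one earlier instance of the change, and no second core to check whether the step travels intact, the expectation rests on compound 2 to compound 1 alone. For compound 4 a step of about a 3.2-fold higher number from compound 3 to compound 4 (0.51 log units; beyond the scatter) is expected, a weakening of a similar size to the earlier one. Compound 4 is accordingly estimated at 5500 nM in this assay, with a likely range of 2500 nM to 13000 nM.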

Compound 4, half-maximal inhibitory concentration: 31900 nM
Beside the measured number, compound 4's estimate is 5.8-fold (0.76 log units) below it; the whole stated range lies below it.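

In this assay, isopropyl in place of the group of 7 heavy atoms gives a 19-fold higher number from compound 3 to compound 4 (1.27 log units; beyond the scatter), and octyl in place of hydrogen on the saturated chain carbon gives a 16-fold higher number from compound 1 to compound 4 (1.19 log units; beyond the scatter), so the direction of the first change holds on the second core while its size does not: the same change on two cores in this assay, a 3.5-fold higher number (0.54 log units; beyond the scatter) from compound 2 to compound 1 and a 19-fold higher number (1.27 log units; beyond the scatter) from compound 3 to compound 4, 5.4-fold (0.73 log units) apart, beyond the scatter of two such steps
The octyl change reads the same way, with the same direction on both cores and a different size: the same change on two cores in this assay, a 2.9-fold higher number (0.46 log units; beyond the scatter) from compound 2 to compound 3 and a 16-fold higher number (1.19 log units; beyond the scatter) from compound 1 to compound 4, 5.4-fold (0.73 log units) apart, beyond the scatter of two such steps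
The two changes therefore do not add independently here, and a step taken from one core gives its direction but not its size on the other; a single pair of cores in one assay does not show why the steps differ, or whether this holds for other pairs in the series.

The compounds shown leave open whether the gap between the steps grows gradually with chain length or appears only at the longer chain. An amine or a carboxylic acid in place of isopropyl, on both chain lengths, would show whether other groups at this place follow the same pattern.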